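Dimethylamino in Place of Methyl on a Nucleoside Core

The source may report more compounds than this note shows. Statements on the series, on what has been measured and on what is new or still open speak of the compounds shown alone.

Compound 1 `CN(C)c1ncnc2c1c(-c1ccoc1)cn2[C@@H]1O[C@H](CO)[C@@H](O)[C@H]1O`: 12500 nM
Compound 2 `C#Cc1cn([C@@H]2O[C@H](CO)[C@@H](O)[C@H]2O)c2ncnc(N(C)C)c12`: 1320 nM
Compound 3 `Cc1ncnc2c1c(-c1cccs1)cn2[C@@H]1O[C@H](CO)[C@@H](O)[C@H]1O`: > 15000 nM (a limit)

Three compounds sharing a sugar-bearing core were tested in a functional assay on HepG2 cells (Homo sapiens) for antiproliferative activity, read by XTT assay, with a stated time of 72 h; on this read-out higher numbers stand for weaker inhibition and lower numbers for stronger inhibition. Compound 1 gives 12500 nM. Within the data shown here, compound 2 gives 1320 nM, and the one measured step, a 9.5-fold lower number from compound 1 to compound 2 (0.98 log units; beyond the scatter), shows that an ethynyl in place of furan-3-yl on an aromatic carbon strengthens inhibition. For compound 3 only a limit is known, > 15000 nM, so compound 3 stands at the weak end of what this assay can report; this is the limit of > 15000 nM in this assay, at which 1 of the 3 values shown sits.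

Compound 4 `CN(C)c1ncnc2c1c(-c1cccs1)cn2[C@@H]1O[C@H](CO)[C@@H](O)[C@H]1O` differs from compound 3 in one place: dimethylamino in place of methyl on an aromatic carbon. Among the measured compounds shown here, no measured step changes methyl to dimethylamino, so the step from compound 1 to compound 2 does not bear directly on it. For the measured compounds named here, the only guide is compound 1, which carries the same dimethylamino with a different five-membered ring and gives 12500 nM. Compound 4 is therefore expected to land near that weak level, 12000 nM, between 5000 nM and 25000 nM, which would mean an estimated step of an at least 1.2-fold lower number from compound 3 to compound 4 (0.09 log units; that floor lies within the scatter).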

Compound 4, half-maximal inhibitory concentration: > 20000 nM
Compound 4 gave a limit, no number (the forecaster's own chance of this, stated with the estimate: 35%); at least 1.6-fold (0.22 log units) between middle value and limit.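

Compound 3 and compound 4 are both limits of this assay and not numbers, so the step from methyl to dimethylamino cannot be read, and neither can any other step between limits, because each value marks only the edge of the assay: the limit of > 20000 nM in this assay, at which 1 of the 4 values shown sits.

With dimethylamino held in place, thiophen-2-yl in place of ethynyl gives an at least 15-fold higher number from compound 2 to compound 4 (1.18 log units; beyond the scatter), so ethynyl is the group that stands apart among these compounds. Thiophen-2-yl in place of furan-3-yl gives an at least 1.6-fold higher number from compound 1 to compound 4 (0.20 log units; that floor lies within the scatter), so these two rings are not told apart here.

Going by these compounds, it remains open whether dimethylamino and methyl differ when ethynyl is the partner group, a setting that gives a readable number. On these data alone, how a smaller amine such as methylamino, or a methoxy group, would behave on that aromatic carbon also remains open.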